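The source may report more compounds than this note shows. Statements on the series, on what has been measured and on what is new or still open speak of the compounds shown alone.

Measured compounds:

Compound 1, `Cn1cnc(S(=O)(=O)N(Cc2ccc(S(C)(=O)=O)cc2)C2Cc3cc(C#N)ccc3N(Cc3cncn3C)C2)c1`, gives 0.26 h in an in vitro ADME assay on microsomes from liver (Mus musculus) for metabolic stability; on this read-out lower numbers stand for a shorter-lived compound and higher numbers for a longer-lived compound.
Compound 2, `COC(=O)N1CCC(CN(C2Cc3cc(C#N)ccc3N(Cc3cncn3C)C2)S(=O)(=O)c2cn(C)cn2)CC1`, gives 0.09 h in this assay.
Compound 3, `Cn1cnc(S(=O)(=O)N(Cc2ccc(S(C)(=O)=O)cc2)C2Cc3cc(C#N)cnc3N(Cc3cncn3C)C2=O)c1`, gives 0.867 h in this assay.

Compound 1 and compound 2 share a core and differ in one place only. The change is 1-(methoxycarbonyl)piperidin-4-yl in place of 4-(methylsulfonyl)phenyl on a saturated chain carbon bound to a sulfonamide nitrogen. Its effect is a 2.9-fold lower number from compound 1 to compound 2 (0.46 log units; beyond the scatter), so the compound with the piperidinyl group is the shorter-lived of the two.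

Compound 3 carries the same benzyl-type group as compound 1 but sits on a different core; the difference between the two cores is not broken down here. Among the three measured compounds, compound 3 has the highest number in this assay, and its step to each of the other two lies beyond the scatter.

Compound 4, `COC(=O)N1CCC(CN(C2Cc3cc(C#N)cnc3N(Cc3cncn3C)C2=O)S(=O)(=O)c2cn(C)cn2)CC1`, has not yet been measured. It relates to compound 3 as compound 2 relates to compound 1: the change is 1-(methoxycarbonyl)piperidin-4-yl in place of 4-(methylsulfonyl)phenyl on a saturated chain carbon bound to a sulfonamide nitrogen. The place of the change reads the same in both pairs, so this is the same change on a different core. Within the data shown here, the only guide to its size is the one step already seen, a 2.9-fold lower number from compound 1 to compound 2 (0.46 log units; beyond the scatter), which is modest but beyond the scatter. On that basis the step from compound 3 to compound 4 is expected to be of similar size and in the same direction, that is a 2.9-fold lower number from compound 3 to compound 4 (0.46 log units; beyond the scatter), because the starting point is the value of compound 3, 0.867 h. Compound 4 is therefore estimated to give 0.3 h in this assay, with a likely range from 0.15 h to 0.6 h.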

Compound 4, half-life: > 2 h
Compound 4: no number, only a limit; the forecaster's own chance of this, stated with the estimate: 5%; middle value at least 6.6-fold (0.82 log units) away from the limit.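

In this assay compound 4 gives > 2 h, which is a limit of the assay and not a number, and it is the only such value among the compounds shown: the limit of > 2 h in this assay, at which 1 of the 4 values shown sits. Read with that limit, putting 1-(methoxycarbonyl)piperidin-4-yl in place of 4-(methylsulfonyl)phenyl gives an at least 2.3-fold higher number from compound 3 to compound 4 (0.36 log units; beyond the scatter), so the change does not carry over from the core of compound 1 to the core of compound 3, and its direction is reversed: the same change on two cores in this assay, a 2.9-fold lower number (0.46 log units; beyond the scatter) from compound 1 to compound 2 and an at least 2.3-fold higher number (0.36 log units; beyond the scatter) from compound 3 to compound 4, at least 6.6-fold (0.82 log units) apart, beyond the scatter of two such steps This does not show the full size of the step on the core of compound 3, since compound 4 has only a limit, nor which feature of the two cores turns the step around, and with one pair on each core it sets no rule for other groups in this series.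

The compounds shown leave open which of the differences separating the two cores matters, since no compound here sits on a core that carries only some of them. Also open, as far as these compounds go, is whether the reversal holds for other groups on a saturated chain carbon bound to a sulfonamide nitrogen, such as a piperidin-4-yl with a free amine or a phenyl ring bearing a carboxylic acid.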